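Amino substituent on the aromatic core of compound 1

The compounds below may be only part of what the source reports. "The series", "measured", "known", "first", "only" and "open" are said of these compounds alone.

Compound 1 `O=C(COc1cccc2ccccc12)N1CCOCC1` is the reference point of this small set. In a functional assay on the whole organism with Mus musculus as the target, in the elevated plus maze, with a stated time of 24 h, at a dose of 1 mg/kg by the intraperitoneal route (on this read-out higher numbers stand for a stronger effect at the one dose given and lower numbers for a weaker effect), compound 1 gives 62.7%. Compound 2 `CN(C)C(=O)COc1cccc2ccccc12` differs only at the carbonyl carbon, dimethylamino in place of morpholin-4-yl, and in this assay compound 2 gives 52.9%. Within the data shown here, the single measured step, a number 9.8 percentage points lower from compound 1 to compound 2 (within the scatter), is within the scatter, so the two measured numbers cannot be told apart; compound 1 is simply the compound from which the next change is made, with compound 2 its only measured neighbour.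

Compound 3 `Nc1cccc2c(OCC(=O)N3CCOCC3)cccc12` keeps the morpholin-4-yl amide of compound 1 and carries one change on the aromatic core: amino in place of hydrogen on an aromatic carbon. Among the measured compounds shown here, the only measured step concerns the amine on the carbonyl carbon, not the aromatic ring, so no measured step bears on this change. There is no basis for expecting a direction; the expectation is of no step beyond the scatter, and the range must be wide.

Compound 3 is expected to give 60% in this assay, between 35% and 80%. The step this estimate means, a number 2.7 percentage points lower from compound 1 to compound 3 (within the scatter), is expected to lie within the scatter, open to either side.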

Compound 3, a percentage reported as activity, at one dose (the size of the read-out at that dose, not a potency): 43.3%
The estimate for compound 3 lay 16.7 percentage points above the measured number, within the range that was stated.
By their numbers in this assay, from the lowest: compounds 3, 2 and 1 (each within the scatter of the next, the first and the last beyond it).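

In this assay, among these compounds, amino in place of hydrogen on an aromatic carbon comes with a number 19.4 percentage points lower from compound 1 to compound 3 (beyond the scatter) and this is the first step in the set that lies beyond the scatter, as well as the first change made on the aromatic core rather than on the carbonyl carbon. With the morpholin-4-yl amide held fixed, the read-out at the one dose therefore responds to a single added group at this place, ortho to a fused ring and meta to a fused ring, so this part of the core of compound 1 is not indifferent to substitution. Nothing at hand accounts for the size or direction of this step.

The compounds shown leave open whether the step belongs to amino itself or would also follow other groups at this carbon, such as hydroxy, methoxy, fluorine or acetylamino. They also leave open whether amino on another carbon of the core, or the same amino group with the dimethylamino amide of compound 2 in place of the morpholin-4-yl amide, would give a step of similar size.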